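From 1,3-oxazol-2-yl to pyridin-2-yl at the limit

This account rests on a few compounds, and the source may have more. Where it says the series, first, only, none or still open, it means among the compounds named here.

In a toxicity assay on HepG2 2.2.15 cells (Homo sapiens) for cytotoxicity, read by CellTiter-Glo (on this read-out lower numbers stand for higher toxicity in this test and higher numbers for lower toxicity in this test), compound 1 `O=C(Nc1cc(F)c(F)c(F)c1)N1Cc2c(-c3ccc(F)cc3F)cnn2CC1C1CC1` gives 32100 nM. Compound 2 `N#CC1CC(=O)N(c2cnn3c2CN(C(=O)Nc2cc(F)c(F)c(F)c2)C(C2CC2)C3)C1` gives > 200000 nM, which is a limit of the assay. Compound 3 `O=C1CC(c2ncco2)CN1c1cnn2c1CN(C(=O)Nc1cc(F)c(F)c(F)c1)C(C1CC1)C2` gives > 200000 nM, which is also a limit of the assay. Compound 3 therefore has no number of its own and stands at the limit of > 200000 nM in this assay, at which 2 of the 3 values shown sit.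

Compound 4 `O=C1CC(c2ccccn2)CN1c1cnn2c1CN(C(=O)Nc1cc(F)c(F)c(F)c1)C(C1CC1)C2` carries pyridin-2-yl in place of 1,3-oxazol-2-yl on a saturated ring carbon. Two steps show what the 2-oxopyrrolidin-1-yl groups did in place of 2,4-difluorophenyl: an at least 6.2-fold higher number from compound 1 to compound 2 (0.79 log units; beyond the scatter) and an at least 6.2-fold higher number from compound 1 to compound 3 (0.79 log units; beyond the scatter). Compound 4 also carries such a group. The nearest step, at the same saturated ring carbon, is a step that the two limits leave unreadable from compound 2 to compound 3, so it gives no size to carry over. No change beyond the scatter is therefore expected in this assay, although a small move towards lower numbers remains possible. The expected step is an at least 1.1-fold lower number from compound 3 to compound 4 (0.07 log units; that floor lies within the scatter). For compound 4 the estimate is 170000 nM, with an expected range of 60000 nM to 300000 nM.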

Compound 4, half-maximal cytotoxic concentration: 96200 nM
The estimate for compound 4 lay 1.8-fold (0.25 log units) above the measured number; the range from low to high includes it.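

In this assay, the group on this saturated ring carbon now shows a readable effect: an at least 2.0-fold lower number from compound 3 to compound 4 (0.31 log units; beyond the scatter), and an at least 2.0-fold lower number from compound 2 to compound 4 (0.31 log units; beyond the scatter), whereas the step between the cyano and 1,3-oxazol-2-yl compounds cannot be read. Compound 4 is the first compound shown with a 2-oxopyrrolidin-1-yl group to give a number rather than a limit, which puts a size on the exchange for 2,4-difluorophenyl: a 3.0-fold higher number from compound 1 to compound 4 (0.48 log units; beyond the scatter). Compound 2 and compound 3 each remain at a limit, so both steps to compound 4 are only floors: the limit of > 200000 nM in this assay, at which 2 of the 4 values shown sit.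

Going by these compounds, how an amine or a carboxylic acid on this ring carbon would read remains open. Also open, on these data alone, is whether the step follows the ring nitrogen of pyridin-2-yl or the six-membered ring alone, which phenyl at the same carbon would help separate.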